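Isopropyl in place of 3,4-dihydroxyphenyl: expecting compound 4

The compounds below may be only part of what the source reports. "The series", "measured", "known", "first", "only" and "open" are said of these compounds alone.

Among the measured compounds shown here, in a functional assay on SK-BR-3 cells (Homo sapiens) for antiproliferative activity, read by MTT assay, with a stated time of 72 h (on this read-out higher numbers stand for weaker inhibition and lower numbers for stronger inhibition), compound 3 `C/C=C1/[C@H](O[C@@H]2O[C@H](CO)[C@@H](O)[C@H](O)[C@H]2O)OC=C(C(=O)OC)[C@H]1CC(=O)OCCc1ccc(O)c(O)c1` gives 160000 nM, the only actual number in this small set. Compound 1 `C/C=C1/[C@H](O[C@@H]2O[C@H](CO)[C@@H](O)[C@H](O)[C@H]2O)OC=C(C(=O)OC)[C@H]1CC(=O)NCCC` reads > 20000 nM, which is a limit of the assay. Compound 2 `C/C=C1/[C@H](O[C@@H]2O[C@H](CO)[C@@H](O)[C@H](O)[C@H]2O)OC=C(C(=O)OC)[C@H]1CC(=O)OCCC` reads > 15000 nM, which is also a limit. Compound 4 `C/C=C1/[C@H](O[C@@H]2O[C@H](CO)[C@@H](O)[C@H](O)[C@H]2O)OC=C(C(=O)OC)[C@H]1CC(=O)OCCC(C)C` keeps the shared core and alters only the end of the chain on compound 3: isopropyl in place of 3,4-dihydroxyphenyl on a saturated chain carbon, two bonds along the chain from an oxygen next to a carbonyl group. In words, isopropyl stands in place of 3,4-dihydroxyphenyl, so that 2-(3,4-dihydroxyphenyl)ethoxy becomes isopentyloxy. The closest measured change is a step that the limit leaves unreadable from compound 2 to compound 3, made at the same place. Less directly, a step that the limit leaves unreadable from compound 1 to compound 3 and a step that the two limits leave unreadable from compound 1 to compound 2 also bear on it. None of these has a readable size, so the expectation stays loose, and compound 4, with a saturated chain like compound 2, may well return only a limit in this assay. A modest shift towards stronger inhibition is expected, as a 2.7-fold lower number from compound 3 to compound 4 (0.43 log units; beyond the scatter). Compound 4 is estimated at 60000 nM, within an expected range of 15000 nM to 200000 nM.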

Compound 4, half-maximal inhibitory concentration: 9020 nM
Compound 4: middle estimate off by 6.7-fold (0.82 log units), on the high side; measured number outside the range, below it.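

In this assay, among the compounds shown here, where the earlier steps could not be read, the change on a saturated chain carbon, two bonds along the chain from an oxygen next to a carbonyl group, now has a size: an 18-fold lower number from compound 3 to compound 4 (1.25 log units; beyond the scatter), so isopropyl there gives far stronger inhibition than 3,4-dihydroxyphenyl. At the same place, isopropyl in place of methyl gives an at least 1.6-fold lower number from compound 2 to compound 4 (0.22 log units; that floor lies within the scatter), and that floor does not separate the two compounds. On the carbonyl carbon, isopentyloxy in place of propylamino gives an at least 2.2-fold lower number from compound 1 to compound 4 (0.34 log units; beyond the scatter), which places compound 4 ahead of compound 1.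

On these data alone, whether the branched isopropyl end matters, or any saturated chain would serve, stays open, since compound 2 gives only a limit: the limit of > 15000 nM in this assay, at which 1 of the 4 values shown sits. How a plain phenyl, an amine or a carboxylic acid would read at this place also remains open.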